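The source may hold more compounds than are shown below. What is called first, only, known or untested is meant among the compounds shown, and "the series" means these compounds.

Three compounds sharing one core have been examined, along with a fourth that awaits testing. Compound 1 `COc1ccc(OC)c(Sc2ccc3nnc(-c4ccncc4)n3n2)c1` and compound 2 `COc1ccc(OC)c(Sc2ccc3nnc(-c4cnccn4)n3n2)c1` carry no result in an assay on HEK293 cells for inhibition of Leucine-rich repeat serine/threonine-protein kinase 2 (Homo sapiens), read by ELISA, with a stated time of 90 min; on this read-out higher numbers stand for weaker inhibition and lower numbers for stronger inhibition: in this assay compound 1 shows "not determined" (no result reported) and compound 2 shows "not determined" (no result reported), and nothing can be said about them beyond their structures. Going by the values given here, compound 3 `COc1ccc(OC)c(Sc2ccc3nnc(-c4ccsn4)n3n2)c1` is the only one with a number: in this assay compound 3 gives 722 nM, and it therefore stands alone, with no measured neighbour to set it against.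

Compound 4 `COc1ccc(OC)c(Sc2ccc3nnc(-c4cn(C)nc4C)n3n2)c1` has not yet been measured. It differs from compound 3 in a single place: 1,3-dimethyl-1H-pyrazol-4-yl in place of 1,2-thiazol-3-yl on an aromatic carbon. Among the compounds with values here, no pair of measured compounds shows what such an exchange does in this assay, so there is no measured step to lean on, and any expectation must rest on the single value of compound 3 together with the structural change itself. The expected step is a 1.4-fold lower number from compound 3 to compound 4 (0.16 log units; within the scatter), small enough that it need not rise beyond the usual scatter, with the direction left open. On that basis compound 4 is estimated at 500 nM in this assay, with a range from 120 nM to 2000 nM that reflects the uncertainty of a step taken without any measured precedent.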

Compound 4, half-maximal inhibitory concentration: 1260 nM
For compound 4 the middle estimate is 2.5-fold (0.40 log units) below the measured one, within the range that was stated.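

In this assay, going by these compounds alone, the exchange gives a 1.7-fold higher number from compound 3 to compound 4 (0.24 log units; within the scatter) and so supplies the first measured step at this place; the two compounds cannot be told apart here. On this aromatic carbon of the five-membered aromatic ring with 3 nitrogen, the 1,3-dimethyl-1H-pyrazol-4-yl group, with 7 heavy atoms and no sulfur, can therefore replace the 1,2-thiazol-3-yl group, with 5 heavy atoms and one sulfur, without a change this measurement can resolve, although both groups are a single five-membered aromatic ring with 2 hetero atoms and 2 hydrogen-bond acceptors, so this pair tests only a limited kind of change. No independent measurement is available to explain this result.

The compounds shown leave open what each methyl group on the pyrazole contributes on its own, since no compound here carries only one of them. They also leave open whether a group of a different kind at this place, such as a carboxylic acid, a primary amine or a longer alkyl chain, would move the number beyond the usual scatter.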